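The source may hold more compounds than are shown below. What is called first, only, known or untested is meant among the compounds shown, and "the series" means these compounds.

Compound 1 `Nc1nc2ccc(C(=O)C(F)(F)F)cc2s1`: > 10 mg/kg, a limit
Compound 2 `CCn1c(=N)sc2cc(OC(F)(F)F)ccc21`: 5 mg/kg
Compound 3 `COC(=O)Cn1c(=N)sc2cc(OC(F)(F)F)ccc21`: > 10 mg/kg, a limit

In a functional assay on the whole organism with Rattus norvegicus as the target (a lower number here means that less compound is needed, a higher number that more compound is needed for the effect), compound 3 gives > 10 mg/kg, which is a limit and not a number. Compound 3 thus stands at the limit of > 10 mg/kg in this assay, at which 2 of the 3 values shown sit. Compound 4 `CNS(=O)(=O)CCn1c(=N)sc2cc(OC(F)(F)F)ccc21` carries (methylsulfamoyl)methyl in place of methoxycarbonyl on a saturated chain carbon bound to an aromatic nitrogen. Going by the values given here, the only measured step at this place is an at least 2.0-fold higher number from compound 2 to compound 3 (0.30 log units; that floor lies within the scatter). Among the compounds with values here, no measured step involves the entering group, so no clear step beyond the scatter is expected in this assay. The estimated change is a number no higher from compound 3 to compound 4 (the limit leaves the size open). For compound 4 the expected value is 10 mg/kg, with an estimated range from 4 mg/kg to 25 mg/kg.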

Compound 4, dose for half-maximal effect: 4 mg/kg
Beside the measured number, compound 4's estimate is 2.5-fold (0.40 log units) above it; low and high end bracket the measured number.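

In this assay, going by these compounds alone, 2-(methylsulfamoyl)ethyl in place of (methoxycarbonyl)methyl gives an at least 2.5-fold lower number from compound 3 to compound 4 (0.39 log units; beyond the scatter), the first step at this place that is beyond the scatter. From the compounds shown here alone, compound 3 remains a limit and not a number, so the full size of that step stays open: the limit of > 10 mg/kg in this assay, at which 2 of the 4 values shown sit. Methylsulfamoyl in place of hydrogen on the chain gives a 1.3-fold lower number from compound 2 to compound 4 (0.10 log units; within the scatter), so the chain takes this group without a clear change. The compounds shown leave open how a dimethylsulfamoyl group, a carboxylic acid or an amine on this chain would read out, and whether a longer chain would hold the value.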